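A few compounds are considered here, and "the series" means these few. Any claim that something is new, unique, unknown or untested is made for them only; others in the source may bear on it.

Compound 1 `C=CCO/N=C/c1c(N)ncnc1Oc1ccc(NC(=O)C2(C(=O)Nc3ccc(F)cc3)CC2)cc1F` gives 3.65 in a physicochemical assay for lipophilicity, using the shake flask method; on this read-out higher numbers stand for higher lipophilicity and lower numbers for lower lipophilicity. Among the three numbers compound 1 stands second highest: compound 3 `CCCCO/N=C/c1c(N)ncnc1Oc1ccc(NC(=O)C2(C(=O)Nc3ccc(F)cc3)CC2)cc1F` gives 4.2, and compound 2 `Nc1ncnc(Oc2ccc(NC(=O)C3(C(=O)Nc4ccc(F)cc4)CC3)cc2F)c1/C=N/OCC(=O)N1CCOCC1` gives 2.1. Compound 4 `CC(O)CO/N=C/c1c(N)ncnc1Oc1ccc(NC(=O)C2(C(=O)Nc3ccc(F)cc3)CC2)cc1F` differs from compound 1 by 1-hydroxyethyl in place of vinyl on a saturated chain carbon bound to an oxygen on an unsaturated carbon. Among the measured compounds shown here, two measured steps bear on this change, both at the same place: a number 0.55 log units higher from compound 1 to compound 3 (beyond the scatter), and a number 1.55 log units lower from compound 1 to compound 2 (beyond the scatter). The entering 1-hydroxyethyl carries a hydrogen-bond donor and acceptor that the propyl of compound 3 lacks, so a downward step in this assay is expected, though not one as large as the step to compound 2. Compound 4 is therefore estimated at 2.8, between 2.3 and 3.3, which means an expected step of a number 0.85 log units lower from compound 1 to compound 4 (beyond the scatter).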

Compound 4, partition coefficient: 2.75
Compound 4: the middle estimate sits 0.05 log units above what was measured; the measured number falls inside the stated range.
By their numbers in this assay, from the lowest: compound 2; then compound 4; then compound 1; then compound 3.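

In this assay, this position now shows a step down without the (morpholin-4-yl)carbonyl group: 1-hydroxyethyl gives a number 0.90 log units lower from compound 1 to compound 4 (beyond the scatter) and, against propyl, a number 1.45 log units lower from compound 3 to compound 4 (beyond the scatter) in a larger step. The change does not go as far as the (morpholin-4-yl)carbonyl group, with a number 0.65 log units higher from compound 2 to compound 4 (beyond the scatter) remaining. No measured evidence accounts for these steps. As far as these compounds go, whether a longer chain bearing the same hydroxyl, an amine or a carboxylic acid at this position would follow compound 4 or compound 2 remains open.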